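Working notes: swapping the group on a saturated ring carbon

A few compounds are considered here, and "the series" means these few. Any claim that something is new, unique, unknown or untested is made for them only; others in the source may bear on it.

Measured in a physicochemical assay for lipophilicity, measured as octanol-water partition, at pH 7.4; on this read-out lower numbers stand for lower lipophilicity and higher numbers for higher lipophilicity:
- Compound 1 `O=C([C@H](O)CS(=O)(=O)c1ccc2cc(Cl)ccc2c1)N1CCC(N2CCOC2=O)CC1`: 1.75
- Compound 2 `O=C([C@H](O)CS(=O)(=O)c1ccc2cc(Cl)ccc2c1)N1CCC(N2CCCC2)CC1`: 1.56

Compound 2 stands within the scatter of compound 1, so these two numbers give no order. Compound 3 `O=C([C@H](O)CS(=O)(=O)c1ccc2cc(Cl)ccc2c1)N1CCC(N2CCCOC2=O)CC1` has not yet been measured. The change from compound 2 to compound 3 is a group of 7 heavy atoms (4 carbon, 1 nitrogen, 2 oxygen; one six-membered non-aromatic ring with 2 hetero atoms) in place of a group of 5 heavy atoms (4 carbon, 1 nitrogen; one five-membered non-aromatic ring with 1 hetero atom), on a saturated ring carbon. For the measured compounds named here, only one measured step bears on this place: a number 0.19 log units lower from compound 1 to compound 2 (within the scatter), with pyrrolidin-1-yl in place of 2-oxo-1,3-oxazolidin-3-yl on the same saturated ring carbon. Going by the values given here, the entering group is not the one in compound 1, so that step is only a loose guide. No change beyond the scatter is expected in this assay, and any upward direction is weakly held. The expected move is a number 0.24 log units higher from compound 2 to compound 3 (within the scatter). For compound 3 the estimate is 1.8, with an expected range from 1.4 to 2.2.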

Compound 3, distribution coefficient: 1.67
Compound 3: the middle estimate sits 0.13 log units above what was measured; the measured number falls inside the stated range.
By their numbers in this assay, from the lowest: compounds 2, 3 and 1 (each within the scatter of the next).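

In this assay, the six-membered ring with 2 hetero atoms gives a number 0.11 log units higher from compound 2 to compound 3 (within the scatter) when it enters in place of pyrrolidin-1-yl, and a number 0.08 log units lower from compound 1 to compound 3 (within the scatter) when it enters in place of the five-membered ring with 2 hetero atoms. Both steps lie within the scatter, so the three groups on this saturated ring carbon give no order among compound 1, compound 2 and compound 3, whether the entering ring differs from the leaving one in size alone or also in hetero atoms and hydrogen-bond acceptors. No measurement at hand bears on why these numbers stand so close.

As far as these compounds go, whether a carboxylic acid, a primary amine or an open alkyl chain on the same ring carbon would stay within the scatter remains open. From the compounds shown here alone, whether the reading carries over to a different shared core also remains open.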